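The compounds below may be only part of what the source reports. "The series", "measured", "known", "first", "only" and "open" are said of these compounds alone.

Three analogues sharing one core were measured in a functional assay on SN12C cells (Homo sapiens) for cytotoxicity, read by sulforhodamine B assay, with a stated time of 48 h, tested at 10 uM; on this read-out lower numbers stand for a stronger effect and higher numbers for a weaker effect at the one concentration tested. Compound 1 `COc1cc(C)cc(-c2c(-c3ccnc(-c4ccc(C(C)=O)cc4)c3)cnn2CC#N)c1` gives 34%, compound 2 `Cc1cc(O)cc(-c2nn(CC#N)cc2-c2ccnc(-c3ccc(Oc4ccccc4)cc3)c2)c1` gives -87%, and compound 3 `COc1cc(C)cc(-c2nn(CC#N)cc2-c2ccnc(-c3ccc(N(C)C)cc3)c2)c1` gives -8%. Compound 3 therefore stands second highest of the three: compound 1 lies higher by a margin beyond the scatter, and compound 2 lies lower by a larger margin, also beyond the scatter. Compound 4 `Cc1cc(O)cc(-c2nn(CC#N)cc2-c2ccnc(-c3ccc(N(C)C)cc3)c2)c1` differs from compound 3 in one place: hydrogen in place of methyl on an oxygen on an aromatic ring. Going by the values given here, no measured pair shows the same change directly. Compound 2, which also carries the hydroxy group, gives -87%, so a step downward in this assay, beyond the scatter, is expected as a number 32 percentage points lower from compound 3 to compound 4 (beyond the scatter). Compound 4 is estimated at -40%, within a range from -90% to 10%.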

Compound 4, a percentage reported as activity, at one concentration (the size of the read-out at that concentration, not a potency): -29%
For compound 4 the middle estimate is 11 percentage points below the measured one, within the range that was stated.
By their numbers in this assay, from the lowest: compound 2; then compound 4; then compound 3; then compound 1.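

In this assay, the change from methoxy to hydroxy on an aromatic ring can now be read directly with dimethylamino held constant: it gives a number 21 percentage points lower from compound 3 to compound 4 (beyond the scatter), a modest step. With hydroxy held constant, dimethylamino in place of phenoxy on an aromatic carbon gives a number 58 percentage points higher from compound 2 to compound 4 (beyond the scatter), a large step. No measurement here offers an explanation for either step.

On these data alone, it remains open how a longer chain on that oxygen, such as ethoxy, would read. As far as these compounds go, it is also open whether an amine or a carboxylic acid in place of the hydroxy group would move the number in the same direction.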